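The source may hold more compounds than are shown below. What is called first, only, known or untested is meant among the compounds shown, and "the series" means these compounds.

Working notes on the series. Compound 1 `COc1ccc2[nH]c(C(=O)N3CC(=O)N(Cc4ccccc4)[C@@H](CCc4ccccc4)C3)cc2c1` gives 4400 nM in a physicochemical assay for solubility, read by spectrophotometry, in phosphate buffer, with a stated time of 2 h, at pH 7.4; a higher number here means a more soluble compound, a lower number a less soluble compound; among the two numbers in hand it is the lower, the nearest being compound 2 `COc1cccc(CN2C(=O)CN(C(=O)c3cc4cc(OC)ccc4[nH]3)C[C@@H]2CCc2ccccc2)c1`, which in this assay gives 5100 nM. For the measured compounds named here, that pair is the only measured step, a 1.2-fold higher number from compound 1 to compound 2 (0.06 log units; within the scatter), and it is within the scatter. Compound 3 `COc1ccc2[nH]c(C(=O)N3CC(=O)N(Cc4ccccc4)[C@@H](CN4CCN(Cc5ccccn5)CC4)C3)cc2c1` stands apart: in this assay it reaches only a limit, > 100000 nM, and so gives no number. The unmeasured compound 4 `COc1ccc2[nH]c(C(=O)N3CC(=O)N(Cc4ccccc4)[C@@H](CN4CC5CCCC5C4)C3)cc2c1` differs from compound 1 by a group of 8 heavy atoms (7 carbon, 1 nitrogen; one five-membered non-aromatic ring of carbon only, one five-membered non-aromatic ring with 1 hetero atom) in place of a group of 7 heavy atoms (7 carbon; one six-membered aromatic ring of carbon only), on a saturated chain carbon bound to a saturated ring carbon. Going by the values given here, no measured step matches this change; the methoxy step gives no guidance, and the nearest indication is the limit of compound 3 (the limit of > 100000 nM in this assay, at which 1 of the 3 values shown sits), where a group carrying a nitrogen atom in a saturated ring sits on the same saturated chain. On that basis compound 4 is expected to move well upward, with the step of an 11-fold higher number from compound 1 to compound 4 (1.06 log units; beyond the scatter). The estimate for compound 4 is 50000 nM, in the range 12000 nM to 200000 nM, with a real chance that only a limit is reported.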

Compound 4, solubility: 20700 nM
The estimate for compound 4 lay 2.4-fold (0.38 log units) above the measured number; the measured number falls inside the stated range.
By their numbers in this assay, from the lowest: compounds 1 and 2 (each within the scatter of the next); then compound 4. At a limit, above all of these: compound 3.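

For the compounds shown here, the change on a saturated chain carbon bound to a saturated ring carbon gives the first measured step beyond the scatter in this assay: a 4.7-fold higher number from compound 1 to compound 4 (0.67 log units; beyond the scatter). This position therefore responds to a change of group, whereas the methoxy step had shown no movement beyond the scatter. With a nitrogen in a saturated ring at this place, compound 4 also gives a number, while compound 3 reaches only a limit, with no number to compare: the limit of > 100000 nM in this assay, at which 1 of the 4 values shown sits.

The compounds shown do not separate the ring nitrogen from the ring carbons, and a cyclohexyl group or an open-chain dimethylamine at the same place would test that. As far as these compounds go, how a carboxylic acid there would read in this assay also remains open.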